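The source may hold more compounds than are shown below. What is called first, only, known or untested is meant among the compounds shown, and "the series" means these compounds.

Compound 2 `CC(C)Cc1ccc(C(C)C(=O)NCc2ccc(F)cc2)cc1` differs from compound 1 `CC(C)Cc1ccc(C(C)C(=O)NCc2ccccc2)cc1` by a fluoro in place of hydrogen on an aromatic carbon. In an assay on brain for inhibition of Fatty-acid amide hydrolase 1 (Rattus norvegicus), read by scintillation counting, with a stated time of 10 min (on this read-out higher numbers stand for weaker inhibition and lower numbers for stronger inhibition), compound 1 gives 21000 nM. In this assay compound 2 gives 27000 nM. Compound 2 thus stands at the higher of the two numbers recorded so far. That gap, however, is a 1.3-fold higher number from compound 1 to compound 2 (0.11 log units; within the scatter), which lies within the scatter, so the two values cannot be told apart. Compound 3 `CC(C)Cc1ccc(C(C)C(=O)NCc2ccc(Cl)cc2)cc1` follows from compound 2 by chloro in place of fluoro on an aromatic carbon. Among the measured compounds shown here, the only measured step that bears on this change is the earlier halogen step, a 1.3-fold higher number from compound 1 to compound 2 (0.11 log units; within the scatter), and it produced nothing beyond the scatter. On that basis no step beyond the scatter is expected in this assay for the exchange of fluoro for chloro, a 1.1-fold lower number from compound 2 to compound 3 (0.03 log units; within the scatter). Compound 3 is therefore estimated at 25000 nM, with a range from 9000 nM to 70000 nM.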

Compound 3, half-maximal inhibitory concentration: 27000 nM
For compound 3 the middle estimate is 1.1-fold (0.03 log units) below the measured one; the range from low to high includes it.
By their numbers in this assay, from the lowest: compounds 1, 2 and 3 (each within the scatter of the next).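

In this assay, the exchange of fluoro for chloro gives no change at the digits printed from compound 2 to compound 3 (within the scatter), and chloro set against the plain hydrogen gives a 1.3-fold higher number from compound 1 to compound 3 (0.11 log units; within the scatter). The second halogen thus confirms what fluoro alone could only suggest: on this aromatic carbon, para to a large group, hydrogen, fluoro and chloro cannot be told apart, and compounds 1, 2 and 3 sit within the scatter of one another. Nothing available explains why these values stay together.

On these data alone, it remains open whether a group of another kind at this place, such as a methoxy group, an amine or a carboxylic acid, would shift the number beyond the scatter. As far as these compounds go, it is equally open whether a longer chain between the amide nitrogen and the aromatic ring would do so.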